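The source may hold more compounds than are shown below. What is called first, only, known or untested is meant among the compounds shown, and "the series" means these compounds.

Working notes on the series. In a functional assay on aorta (Rattus norvegicus, strain Sprague-Dawley) for inhibition, with a stated time of 20 min (on this read-out higher numbers stand for larger maximal responses and lower numbers for smaller maximal responses), compound 3 `C=CCc1c(O)cc(O)c2c1OC(c1cccc(Br)c1)CC2=O` gives 78.8%, the second highest of the three numbers obtained. Compound 1 `C=CCc1c(O)ccc(C(=O)/C=C/c2ccc(O)cc2)c1O` gives 73.4%, which lies within the usual scatter of the number for compound 3. Compound 2 `O=C1CC(c2cccc(Br)c2)Oc2ccc(O)cc21` gives 91.8%, higher than compound 3 and beyond the scatter. Compound 4 `C=CCc1c(O)cc(O)c2c1OC(c1ccc(O)cc1)CC2=O` remains to be measured in this assay. Against compound 3 it shows (4-hydroxyphenyl in place of 3-bromophenyl on a saturated ring carbon). Going by the values given here, no step between measured compounds bears on this change. Compound 1, the only other carrier of a 4-hydroxyphenyl, gives 73.4%, within the scatter of compound 3. No step beyond the scatter is expected, and the expected step is a number 4.8 percentage points lower from compound 3 to compound 4 (within the scatter). Compound 4 is estimated at 74%, within 60% to 88%.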

Compound 4, largest response reached (Emax), in percent of the reference or control that the assay uses: 9.86%
Compound 4: the middle estimate sits 64.1 percentage points above what was measured, and the stated range ends above it.
By their numbers in this assay, from the lowest: compound 4; then compounds 1 and 3 (each within the scatter of the next); then compound 2.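

In this assay, 4-hydroxyphenyl in place of 3-bromophenyl on a saturated ring carbon gives a number 68.9 percentage points lower from compound 3 to compound 4 (beyond the scatter), the first step available at this place. The number at this position therefore depends strongly on the aryl group it carries, even though the two groups match in heavy-atom count and ring type. As far as these compounds go, whether the step follows the gain of hydroxyl, the loss of bromine or the different placement on the phenyl ring stays open, as does the read-out with a methoxy group or an amine on that phenyl. No measurement in hand accounts for the size of this step.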